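Changing the Amide Tail of a Kinase Binder

The source may report more compounds than this note shows. Statements on the series, on what has been measured and on what is new or still open speak of the compounds shown alone.

Measured so far:
compound 1 `CN(CCCn1ccnc1)C(=O)[C@@H]1CCCN1c1nccc(Nc2ccccc2)n1` gives 6%
compound 2 `Cc1cccc(Oc2ccnc(N3CCN(C(=O)c4c(C)noc4C)CC3)n2)c1` gives 5%
compound 3 `Cc1cc(C(=O)N2CCN(c3ncnc4c3CN(Cc3ccccc3)CC4)CC2)c(C)n1C` gives 7%

All three compounds were tested in an assay on isolated protein for inhibition of ribosomal protein S6 kinase beta-1 (Homo sapiens), read by HTRF, tested at 10 uM; on this read-out lower numbers stand for less inhibition and higher numbers for more inhibition at the one concentration tested (going by the name of the read-out). Compound 1, with 6% in this assay, cannot be told apart from compound 2 or compound 3: each of the three numbers lies within the usual scatter of the other two, so the three numbers are level. Put simply, all three show only weak inhibition at the single concentration tested.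

Compound 4 `CN(C)CC(C)(C)CNC(=O)[C@@H]1CCCN1c1nccc(Nc2ccccc2)n1` keeps the whole of compound 1 except for the tail attached to the amide carbonyl. The change is (2-((dimethylamino)methyl)-2-methylpropyl)amino in place of (3-(1H-imidazol-1-yl)propyl)(methyl)amino on a carbonyl carbon. A ring-bearing side chain is thus replaced by an open chain that carries a hydrogen-bond donor where the old group had none.

For the measured compounds named here, with no pair of measured compounds differing in one place, there is no measured step to lean on. Given that compound 1 itself shows only 6% and that its neighbours look no different, the step of no change at the digits printed from compound 1 to compound 4 (within the scatter) is expected to be none beyond the scatter. Compound 4 is therefore expected to give 6%, within a range from -4% to 16%.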

Compound 4, a percentage reported as inhibition, at one concentration (the size of the read-out at that concentration, not a potency): 13%
Compound 4: the middle estimate sits 7 percentage points below what was measured, within the range that was stated.
By their numbers in this assay, from the lowest: compounds 2, 1, 3 and 4 (each within the scatter of the next).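

In this assay, the exchange of the tail on the carbonyl carbon gives a number 7 percentage points higher from compound 1 to compound 4 (within the scatter), so the two tails cannot be told apart on this read-out. For the compounds shown here, this is the first comparison at this position in which only one part of the structure differs, and it shows that the open chain (2-((dimethylamino)methyl)-2-methylpropyl)amino, with no ring and a hydrogen-bond donor, can stand in place of (3-(1H-imidazol-1-yl)propyl)(methyl)amino, with its five-membered aromatic ring and no donor, without a difference beyond the usual scatter. Nothing measured here bears on what lies behind the two numbers.

A single step within the scatter leaves open whether this position has any real influence on inhibition of this kinase, and whether the shared core can reach more than weak inhibition at the one concentration tested. A morpholine or a carboxylic acid at the end of the chain, placed on the same carbonyl carbon of the core of compound 1, would test whether a different tail can give a step beyond the scatter.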